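The source may report more compounds than this note shows. Statements on the series, on what has been measured and on what is new or still open speak of the compounds shown alone.

Measured in a functional assay (muscle tissue) with Cavia porcellus as the target; a higher number here means a weaker inhibitor, a lower number a stronger inhibitor:
compound 1 `CC1=NC(C)=C([N+](=O)[O-])C(c2ncccc2[N+](=O)[O-])/C1=C(/O)OC(C)C` — 3770 nM
compound 2 `CC1=NC(C)=C([N+](=O)[O-])C(c2cccc(Cl)n2)/C1=C(/O)OCCc1ccccc1` — 1510 nM
compound 3 `CC1=NC(C)=C([N+](=O)[O-])C(c2ncccc2Cl)/C1=C(/O)OCCc1ccccc1` — 5170 nM

Compound 3 is not separated from compound 1, the gap between the two being within the scatter; against compound 2 it is the weaker inhibitor, a 3.4-fold higher number from compound 2 to compound 3 (0.53 log units; beyond the scatter) lying beyond the scatter. Compound 4 `CC1=NC(C)=C([N+](=O)[O-])C(c2ncccc2[N+](=O)[O-])/C1=C(/O)OCCc1ccccc1` carries nitro in place of chloro on an aromatic carbon. Among the compounds with values here, no measured step exchanges these two groups on their own, so the size of this change is unknown from the steps at hand. Compound 1 carries the same 3-nitropyridin-2-yl ring with a different ester, and its value beside that of compound 3 lies within the scatter, which argues against a large move. The estimate for compound 4 is 4000 nM (range 1500 nM to 11000 nM). This corresponds to an expected 1.3-fold lower number from compound 3 to compound 4 (0.11 log units; within the scatter).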

Compound 4, half-maximal inhibitory concentration: 77700 nM
Compound 4: middle estimate off by 19-fold (1.29 log units), on the low side, outside the stated range (above it).
By their numbers in this assay, from the lowest: compound 2; then compounds 1 and 3 (each within the scatter of the next); then compound 4.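

In this assay this position proves sensitive to the group it carries: nitro in place of chloro gives a 15-fold higher number from compound 3 to compound 4 (1.18 log units; beyond the scatter). The 3-nitropyridin-2-yl ring in place of 6-chloropyridin-2-yl gives a larger step still, a 51-fold higher number from compound 2 to compound 4 (1.71 log units; beyond the scatter). With the 3-nitropyridin-2-yl ring held, the ester also counts, phenethyl in place of isopropyl giving a 21-fold higher number from compound 1 to compound 4 (1.31 log units; beyond the scatter). Nothing on hand accounts for these steps. On these data alone, whether a methyl or an amine at this ring position would behave like chloro or like nitro remains open.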